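Nitro for Fluoro: Expected Cytotoxicity of Compound 3

The compounds below may be only part of what the source reports. "The series", "measured", "known", "first", "only" and "open" are said of these compounds alone.

Measured compounds:
- compound 1, `Cc1cc(=O)oc2cc(OCc3cn(-c4ccccc4F)nn3)ccc12`, > 100 ug/mL
- compound 2, `Cc1cc(=O)oc2cc(OCc3cn(-c4ccc(OC(F)(F)F)cc4)nn3)ccc12`, > 100 ug/mL

Of the compounds shown here, two have so far been tested in an ADME assay on Huh-7 cells (Homo sapiens) for cytotoxicity, read by MTT assay, with a stated time of 72 h; on this read-out lower numbers stand for higher toxicity in this test and higher numbers for lower toxicity in this test. Compound 1 (`Cc1cc(=O)oc2cc(OCc3cn(-c4ccccc4F)nn3)ccc12`) gives only a limit in this assay, > 100 ug/mL, not a number. Compound 2 (`Cc1cc(=O)oc2cc(OCc3cn(-c4ccc(OC(F)(F)F)cc4)nn3)ccc12`) likewise gives only a limit in this assay, > 100 ug/mL. Both results thus sit at the limit of > 100 ug/mL in this assay, at which 2 of the 2 values shown sit, so compound 1 cannot be set apart from compound 2 on these numbers; the two stand together at the limit of what this assay can report.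

Compound 3 (`Cc1cc(=O)oc2cc(OCc3cn(-c4ccccc4[N+](=O)[O-])nn3)ccc12`) differs from compound 1 in a single change: nitro in place of fluoro on an aromatic carbon, in words nitro in place of fluoro on an aromatic carbon. Within the data shown here, no measured pair of compounds shows a step of this kind, so there is no measured step to lean on. Because compound 1 and compound 2 both sit at the limit of > 100 ug/mL in this assay, at which 2 of the 2 values shown sit, the expected step from compound 1 to compound 3 is a number no higher from compound 1 to compound 3 (the limit leaves the size open), that is, none beyond the scatter. For compound 3 the estimate in this assay is 100 ug/mL, with a range from 40 ug/mL to 250 ug/mL, and it is expected that the assay will most likely again report only a limit.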

Compound 3, half-maximal cytotoxic concentration: > 100 ug/mL
Compound 3: a limit, no number; the forecaster's own chance of this, stated with the estimate: 75%; the middle value sits exactly at the limit.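

No step from compound 1 to compound 3 can be read, because each result is a limit rather than a number: the limit of > 100 ug/mL in this assay, at which 3 of the 3 values shown sit.

The compounds shown leave open whether nitro in place of fluoro on an aromatic carbon changes the result in this assay at all, and how compound 1, compound 2 and compound 3 rank against one another.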